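The compounds below may be only part of what the source reports. "The series", "measured", "known", "first", "only" and "open" are said of these compounds alone.

Measured in a functional assay on MCF7 cells (Homo sapiens) for antiproliferative activity, read by MTT assay, with a stated time of 48 h; on this read-out lower numbers stand for stronger inhibition and higher numbers for weaker inhibition:
- compound 1 `O=C(NS(=O)(=O)c1ccccc1)c1cccnc1`: 14400 nM
- compound 2 `Cc1ccc(S(=O)(=O)NC(=O)c2cccnc2)cc1`: 12000 nM

Among the compounds with values here, compound 1 and compound 2 lie within the scatter of each other, so compound 1 stands level with the only other measured compound in this assay. Both numbers are in the same range, and the series offers no wider spread to place them against.

The next compound is compound 3 `O=C(NS(=O)(=O)c1ccccc1)c1cncc(Br)c1`, which keeps the core of compound 1 and changes one place: bromo in place of hydrogen on an aromatic carbon. In words, this is bromo in place of hydrogen on an aromatic carbon, on the six-membered aromatic ring with 1 nitrogen, two atoms from the ring nitrogen.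

Within the data shown here, only one measured step bears on this change, and only loosely: a 1.2-fold lower number from compound 1 to compound 2 (0.08 log units; within the scatter). Among the measured compounds shown here, that step also replaced hydrogen on an aromatic carbon, but its methyl did not go on the ring with the nitrogen, and no measured step touches that ring. A small step in this assay is therefore expected, with a slight lean towards a lower number that rests on judgement and not on data from this series. The expected step is a 1.5-fold lower number from compound 1 to compound 3 (0.18 log units; within the scatter). Compound 3 is estimated at 9500 nM, with an expected range from 3500 nM to 22000 nM.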

Compound 3, half-maximal inhibitory concentration: 12900 nM
Compound 3: middle estimate off by 1.4-fold (0.13 log units), on the low side; low and high end bracket the measured number.
By their numbers in this assay, from the lowest: compounds 2, 3 and 1 (each within the scatter of the next).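

In this assay, within the data shown here, the first measured change on the six-membered aromatic ring with 1 nitrogen, bromo in place of hydrogen on an aromatic carbon two atoms from the ring nitrogen, gives a 1.1-fold lower number from compound 1 to compound 3 (0.05 log units; within the scatter). This position therefore takes one bromine, a single heavy atom with no ring, without a step beyond the scatter, and this adds to a 1.2-fold lower number from compound 1 to compound 2 (0.08 log units; within the scatter), which concerned the other aromatic ring and also stays within the scatter. No measured information on these compounds speaks to the reason for this result.

Still open, going by these compounds, is whether any group at this position moves the number beyond the scatter, since an amine, a carboxylic acid or a longer chain in the same place would test far more than a single bromine can. On these data alone, it is also open whether bromo and methyl together, each on its own ring of the core of compound 1, would stay as close to compound 1 as each single change does, and whether the flat picture in this assay holds for larger changes on either ring.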